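The source may hold more compounds than are shown below. What is called first, only, known or untested is meant among the compounds shown, and "the series" means these compounds.

Three compounds share one core and differ only in the aryl group carried on the amine nitrogen in a ring. Compound 1 `Nc1scc(CN2CCN(c3ccc(Cl)cc3Cl)CC2)c1C(=O)c1ccc(Cl)cc1` gives -74% in a functional assay on CHO cells with adenosine receptor A1 (Homo sapiens) as the target, read by cAMP accumulation and immunoassay, with a stated time of 6 min, tested at 10 uM; a higher number here means a weaker effect of the compound at the concentration tested, a lower number a stronger effect. Compound 2 `Nc1scc(CN2CCN(c3ccc(Cl)cc3F)CC2)c1C(=O)c1ccc(Cl)cc1` gives -81% in this assay, and the step of a number 7 percentage points lower from compound 1 to compound 2 (within the scatter) lies within the scatter. Compound 3 `Nc1scc(CN2CCN(c3cccc4ccccc34)CC2)c1C(=O)c1ccc(Cl)cc1`, which carries naphthalen-1-yl, stands highest of the three: in this assay compound 3 gives -21%, and the steps of a number 53 percentage points higher from compound 1 to compound 3 (beyond the scatter) and a number 60 percentage points higher from compound 2 to compound 3 (beyond the scatter) are both large and beyond the scatter.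

Compound 4 `Nc1scc(CN2CCN(c3ccccc3F)CC2)c1C(=O)c1ccc(Cl)cc1` has not been measured in this assay. It differs from compound 3 in one place: 2-fluorophenyl in place of naphthalen-1-yl on an amine nitrogen in a ring. The two measured steps that bear on this change are those from compound 1 and from compound 2 to compound 3, each a large rise on going to naphthalen-1-yl; the change to compound 4 runs the other way, back to a single six-membered aromatic ring bearing a halogen, though one that differs from the rings of compound 1 and compound 2. A large step downward is therefore expected, of about a number 39 percentage points lower from compound 3 to compound 4 (beyond the scatter). Compound 4 is estimated to give -60% in this assay, with a range from -85% to -25%.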

Compound 4, a percentage reported as activity, at one concentration (the size of the read-out at that concentration, not a potency): -15%
For compound 4 the middle estimate is 45 percentage points below the measured one; the measured number lies above the stated range.
By their numbers in this assay, from the lowest: compounds 2 and 1 (each within the scatter of the next); then compounds 3 and 4 (each within the scatter of the next).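

The result shows that going from two aromatic rings to one does not by itself bring the number down: 2-fluorophenyl and naphthalen-1-yl on the amine nitrogen in a ring cannot be told apart, with a number 6 percentage points higher from compound 3 to compound 4 (within the scatter). The large change instead goes with the chloro named in the 4-chloro-2-fluorophenyl and 2,4-dichlorophenyl groups, since hydrogen in place of that chloro gives a number 66 percentage points higher from compound 2 to compound 4 (beyond the scatter), and the 2-fluorophenyl group in place of 2,4-dichlorophenyl gives a similar rise, with a number 59 percentage points higher from compound 1 to compound 4 (beyond the scatter). Among these compounds, compounds 1, 2 and 4 therefore indicate that a single halogenated ring is not enough and that the low numbers so far belong to the two rings that carry this chloro, though no measurement given here explains why.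

The compounds shown leave open whether the chloro can do this alone, as in a 4-chlorophenyl group with hydrogen in place of the other halogen. They also leave open whether a bromo, a methyl, a methoxy or a nitrile in place of that chloro would hold the number low.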